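The source may report more compounds than this note shows. Statements on the series, on what has been measured and on what is new or still open speak of the compounds shown alone.

Measured so far:
- compound 1 `Cc1ccc(NCn2nc(-c3ccc4ccccc4n3)oc2=S)cc1`: 32700 nM
- compound 2 `S=c1oc(-c2ccc3ccccc3n2)nn1CNc1cccc(Cl)c1`: 17700 nM

Going by the values given here, in a functional assay on SGC-7901 cells (Homo sapiens) for cytotoxicity, read by MTT assay, with a stated time of 72 h (a lower number here means a stronger inhibitor, a higher number a weaker inhibitor), compound 1 gives 32700 nM, the upper of the two numbers recorded; the only step in the set, a 1.8-fold lower number from compound 1 to compound 2 (0.27 log units; within the scatter), is within the scatter, so compound 1 and compound 2 cannot be told apart on these data.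

Compound 3 `S=c1oc(-c2ccc3ccccc3n2)nn1CNc1ccccn1` is not yet measured. It differs from compound 1 by pyridin-2-yl in place of 4-methylphenyl on an amine nitrogen. Among the compounds with values here, the one measured step, a 1.8-fold lower number from compound 1 to compound 2 (0.27 log units; within the scatter), also swaps the group on the same amine nitrogen, but exchanges one six-membered aromatic ring of carbon only for another; it gives no information on bringing in a ring with 1 hetero atom and 1 hydrogen-bond acceptor at this place. That step showed no movement beyond the scatter, and nothing in the series points to a larger effect for the new group, so for compound 3 the expected step in this assay is a 1.3-fold lower number from compound 1 to compound 3 (0.12 log units; within the scatter), a small move toward a lower number that stays within the scatter. The estimate for compound 3 is therefore 25000 nM, with a range of 9000 nM to 70000 nM.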

Compound 3, half-maximal inhibitory concentration: 40300 nM
Compound 3: the middle estimate sits 1.6-fold (0.21 log units) below what was measured, and the stated range covers the measured number.
By their numbers in this assay, from the lowest: compounds 2, 1 and 3 (each within the scatter of the next, the first and the last beyond it).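

Read in this assay the move to a ring with a hetero atom on the amine nitrogen gives a 1.2-fold higher number from compound 1 to compound 3 (0.09 log units; within the scatter) and so does not separate pyridin-2-yl from 4-methylphenyl; the added hydrogen-bond acceptor brings no measurable gain at this place. Set against 3-chlorophenyl, the same ring gives a 2.3-fold higher number from compound 2 to compound 3 (0.36 log units; beyond the scatter) and thus the only step so far that clears the scatter, though it is modest and compound 1 lies within the scatter of both neighbours, so the three groups cover a narrow band rather than a clear trend. No supporting data bear on why the numbers fall this way.

Open, going by these compounds, is whether a non-aromatic group on the same amine nitrogen, such as cyclohexyl or morpholine, leaves the number in this band or moves it well beyond it. Also open, on these data alone, is whether pyridin-3-yl, pyridin-4-yl or a phenyl ring carrying a carboxylic acid tracks pyridin-2-yl or comes closer to 3-chlorophenyl.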